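Replacing the benzyloxy group of compound 3

The source may report more compounds than this note shows. Statements on the series, on what has been measured and on what is new or still open speak of the compounds shown alone.

In a functional assay on Shh Light II cells (Mus musculus) for inhibition, read by a luciferase reporter (a lower number here means a stronger inhibitor, a higher number a weaker inhibitor), compound 3 `O=C(OCc1ccccc1)N1CCC(c2nc(-c3ccc4ccccc4n3)no2)CC1` reads > 2500 nM as a limit of the assay and not a number.

Two relatives share its core. Compound 1 `O=C(NC1CCC(O)CC1)N1CCC(c2nc(-c3ccc4ccccc4n3)no2)CC1` gives 2700 nM and compound 2 `O=C(OC1CCCCC1)N1CCC(c2nc(-c3ccc4ccccc4n3)no2)CC1` gives 580 nM in this assay on the same scale.

Compound 4 `Cc1noc(C)c1NC(=O)N1CCC(c2nc(-c3ccc4ccccc4n3)no2)CC1` has not been measured yet. It keeps the core and changes one group on the carbonyl carbon, with (3,5-dimethyl-1,2-oxazol-4-yl)amino in place of benzyloxy on a carbonyl carbon in the new structure.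

Two measured steps at this same carbonyl carbon bear on the change. Cyclohexyloxy in place of (4-hydroxycyclohexyl)amino gave a 4.7-fold lower number from compound 1 to compound 2 (0.67 log units; beyond the scatter) as its result, and benzyl in place of cyclohexyl gave an at least 4.3-fold higher number from compound 2 to compound 3 (0.63 log units; beyond the scatter) as its result. Both are modest in size, so changes at this place have moved the number but not dramatically.

Within the data shown here, compound 1 at 2700 nM is the only measured compound with an amino group on that carbon, as compound 4 has, and it offers the closest guide.

What is expected in this assay is an at least 2.0-fold lower number from compound 3 to compound 4 (0.31 log units; beyond the scatter) of modest size, toward a lower number. Compound 4 is estimated at 1200 nM with 250 nM to 5000 nM as its expected range.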

Compound 4, half-maximal inhibitory concentration: 3000 nM
For compound 4 the middle estimate is 2.5-fold (0.40 log units) below the measured one, and the stated range covers the measured number.
By their numbers in this assay, from the lowest: compound 2; then compounds 1 and 4 (each within the scatter of the next).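

Compound 3 is held only as a limit of the assay, so the step from it to compound 4 cannot be read: the limit of > 2500 nM in this assay, at which 1 of the 4 values shown sits.

The readable steps give a clearer picture. In this assay, 3,5-dimethyl-1,2-oxazol-4-yl in place of 4-hydroxycyclohexyl on the amide-type nitrogen gives a 1.1-fold higher number from compound 1 to compound 4 (0.05 log units; within the scatter), so these two very different groups on that nitrogen cannot be told apart by this read-out. Replacing the cyclohexyloxy group with (3,5-dimethyl-1,2-oxazol-4-yl)amino gives a 5.2-fold higher number from compound 2 to compound 4 (0.71 log units; beyond the scatter), which, taken with a 4.7-fold lower number from compound 1 to compound 2 (0.67 log units; beyond the scatter), leaves both amino compounds on the higher side of compound 2, although the benzyloxy group of compound 3 shows that an oxygen on the carbonyl carbon does not by itself bring a low number.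

Whether the number is set by the oxygen or nitrogen link, or by the group it carries, stays open, since no two compounds shown have the same group on both links. A cyclohexylamino group, matched with compound 2, or a benzylamino group, matched with compound 3, would separate these two effects.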